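A few compounds are considered here, and "the series" means these few. Any claim that something is new, unique, unknown or untested is made for them only; others in the source may bear on it.

Measured compounds in a functional assay on QGY7701 cells (Homo sapiens) for cytotoxicity, read by MTT assay, with a stated time of 24 h; on this read-out lower numbers stand for stronger inhibition and higher numbers for weaker inhibition:

compound 1, `C=CC1=C(C(=O)NCc2ccccc2)C(c2ccc(OC)cc2)OC1`. In this assay compound 1 gives > 100000 nM, a limit of the assay and not a number.

compound 2, `C=CC1=C(C(=O)NC2CCCCC2)C(c2ccc(OC)cc2)OC1`. In this assay compound 2 gives > 100000 nM, likewise a limit of the assay.

Compound 2 therefore stands at the limit of this assay; no number is known for it. The step that the two limits leave unreadable from compound 1 to compound 2 cannot be sized because the limit of > 100000 nM in this assay, at which 2 of the 2 values shown sit, covers both of its ends.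

Compound 3, `C=CC1=C(C(=O)NCC(C)C)C(c2ccc(OC)cc2)OC1`, is reached from compound 2 by isobutyl in place of cyclohexyl on an amide-type nitrogen. For the measured compounds named here, the only measured step that bears on this change is a step that the two limits leave unreadable from compound 1 to compound 2, whose size is not readable, so no direction can be taken from it. The expected step, a number no higher from compound 2 to compound 3 (the limit leaves the size open), is estimated to lie within the scatter, with a further limit the most likely outcome. Compound 3 is expected to give about 100000 nM in this assay, within a range of 40000 nM to 300000 nM.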

Compound 3, half-maximal inhibitory concentration: > 100000 nM
Compound 3: a limit, no number; the forecaster's own chance of this, stated with the estimate: 85%; the middle value lies on the limit itself.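

No new step can be read among compound 1, compound 2 and compound 3, as all three values are limits and not numbers: the limit of > 100000 nM in this assay, at which 3 of the 3 values shown sit.

The compounds shown leave open how benzyl, cyclohexyl and isobutyl on the amide-type nitrogen compare in this assay, and what structure on the shared core would give a number there.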